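Swapping ethoxy for dimethylamino on the urea-linked phenyl ring

This account rests on a few compounds, and the source may have more. Where it says the series, first, only, none or still open, it means among the compounds named here.

Compound 1 `Cc1ccc(NC(=O)Nc2cccc(CNc3nccnc3Cl)c2)cc1C`: 10700 nM
Compound 2 `CCOc1ccc(NC(=O)Nc2cccc(CNc3nccnc3Cl)c2)cc1`: 7050 nM
Compound 3 `O=C(Nc1cccc(CNc2nccnc2Cl)c1)Nc1ccc(Cl)cc1Br`: 6720 nM

Three compounds share one core and differ only in the aryl group on an amide-type nitrogen. In a functional assay on HepG2 cells (Homo sapiens) for antiproliferative activity, read by MTT assay, with a stated time of 48 h (a lower number here means a stronger inhibitor, a higher number a weaker inhibitor), compound 2 sits between the others: compound 3 is nearest (a 1.0-fold lower number from compound 2 to compound 3 (0.02 log units; within the scatter)) and compound 1 furthest (a 1.5-fold lower number from compound 1 to compound 2 (0.18 log units; within the scatter)), both within the scatter.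

Compound 4 `CN(C)c1ccc(NC(=O)Nc2cccc(CNc3nccnc3Cl)c2)cc1` is the next variation. It differs from compound 2 by dimethylamino in place of ethoxy on an aromatic carbon

The two steps that bear on this, a 1.5-fold lower number from compound 1 to compound 2 (0.18 log units; within the scatter) and a 1.0-fold lower number from compound 2 to compound 3 (0.02 log units; within the scatter), each exchanged the whole aryl group and stayed within the scatter. A smaller exchange of one substituent is therefore expected to give no step beyond the scatter in this assay, so compound 4 is expected at 7000 nM (range 3500 nM to 14000 nM), an expected step of a 1.0-fold lower number from compound 2 to compound 4 (0.00 log units; within the scatter).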

Compound 4, half-maximal inhibitory concentration: > 40000 nM
Compound 4: only a limit was reported (the forecaster's own chance of this, stated with the estimate: 5%); middle value at least 5.7-fold (0.75 log units) from the limit.
By their numbers in this assay, from the lowest: compounds 3, 2 and 1 (each within the scatter of the next). At a limit, above all of these: compound 4.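

In this assay, whole aryl exchanges had stayed within the scatter, yet here one substituent on the ring, para to a large group, changes the result clearly: an at least 5.6-fold higher number from compound 2 to compound 4 (0.75 log units; beyond the scatter), although ethoxy and dimethylamino have the same count of heavy atoms. The other two aryl groups also separate from 4-(dimethylamino)phenyl, with an at least 5.9-fold higher number from compound 3 to compound 4 (0.77 log units; beyond the scatter) and an at least 3.7-fold higher number from compound 1 to compound 4 (0.57 log units; beyond the scatter). The reading for compound 4 is a limit of the assay, not a number: the limit of > 40000 nM in this assay, at which 1 of the 4 values shown sits.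

Going by these compounds, whether an unsubstituted amine, a methoxy group or a longer alkoxy chain at this place would behave like ethoxy or like dimethylamino stays open.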